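Swapping One Ring Group on a Growth Inhibitor

The source may hold more compounds than are shown below. What is called first, only, known or untested is meant among the compounds shown, and "the series" means these compounds.

Measured so far:
Compound 1 `O=C(/C(=C\c1c(O)cc(O)cc1O)Sc1ccc(Br)cc1)c1ccc(Cl)cc1`: 50000 nM
Compound 2 `Cc1cc(C)cc(/C=C(/Sc2ccc(Br)cc2)C(=O)c2ccc(Cl)cc2)c1`: 10000 nM
Compound 3 `Cc1cc(C)cc(/C=C(/SCc2ccc(Cl)cc2)C(=O)c2ccc(Cl)cc2)c1`: 10000 nM

In a functional assay on DU-145 cells (Homo sapiens) for inhibition, read by trypan blue exclusion, with a stated time of 96 h (on this read-out higher numbers stand for weaker inhibition of growth and lower numbers for stronger inhibition of growth), compound 2 stands level with compound 3, and the two share the lowest number of the three. Compound 4 `O=C(/C(=C\c1ccc(F)cc1F)Sc1ccc(Br)cc1)c1ccc(Cl)cc1` differs from compound 2 in a single group: 2,4-difluorophenyl in place of 3,5-dimethylphenyl on a double-bonded chain carbon bound to a double-bonded chain carbon. In words, 2,4-difluorophenyl takes the place of 3,5-dimethylphenyl.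

Two measured steps can guide an expectation. The more relevant one changes the group at this same place: a 5.0-fold lower number from compound 1 to compound 2 (0.70 log units; beyond the scatter). It shows that a swap here can shift the number by a modest amount. The other step changes the group on sulfur instead: no change at the digits printed from compound 2 to compound 3 (within the scatter). It says little about the new swap, which happens elsewhere in the molecule. Among the measured compounds shown here, no measured compound carries 2,4-difluorophenyl, so the data do not settle the direction of any shift. The best expectation is therefore little or no movement, with room on both sides of about the size seen at this place before.

The expected step is no change at the digits printed from compound 2 to compound 4 (within the scatter). For compound 4 the estimate is 10000 nM, with an expected range from 3000 nM to 30000 nM.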

Compound 4, concentration for 50% growth inhibition: 1000 nM
For compound 4 the middle estimate is 10-fold (1.00 log units) above the measured one; the measured number lies below the stated range.
By their numbers in this assay, from the lowest: compound 4; then compounds 2 and 3 (each within the scatter of the next); then compound 1.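

In this assay, 3,5-dimethylphenyl and 2,4-difluorophenyl have the same computed counts of heavy atoms, rings, hydrogen-bond donors and acceptors, yet exchanging them on a double-bonded chain carbon bound to a double-bonded chain carbon gives a 10-fold lower number from compound 2 to compound 4 (1.00 log units; beyond the scatter). Replacing 2,4,6-trihydroxyphenyl at this same place gives a 50-fold lower number from compound 1 to compound 4 (1.70 log units; beyond the scatter), so compounds 1, 2 and 4 show a wider span at this place than the earlier step between compound 1 and compound 2 had revealed. Nothing measured here accounts for the effect of this change on growth inhibition.

Still open, as far as these compounds go, is whether both fluorines are needed, or whether a phenyl ring carrying a single fluorine, an amine or a carboxylic acid would give a similar number at this place. It is also unknown whether 2,4-difluorophenyl would have the same effect alongside the 4-chlorobenzyl group on sulfur found in compound 3.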